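The source may report more compounds than this note shows. Statements on the series, on what has been measured and on what is new or still open speak of the compounds shown alone.

Working notes on the series. Compound 1 `Cc1ccc(OCCCCOc2ccc(C(=O)CC(C)(C)C)c(O)c2C)cc1C(=O)O` gives 210 nM in an assay for positive allosteric modulation of metabotropic glutamate receptor 2 (Rattus norvegicus); on this read-out higher numbers stand for an effect only at larger amounts of compound and lower numbers for an effect already at smaller amounts. Compound 2 `Cc1c(OC[C@H](C)COc2ccc(F)c(C(=O)O)c2)ccc(C(=O)CC(C)(C)C)c1O` gives 294 nM in this assay, and compound 3 `Cc1c(OC[C@@H](C)COc2ccc(F)c(C(=O)O)c2)ccc(C(=O)CC(C)(C)C)c1O` gives 112 nM in this assay. Compound 3 stands at the low end of the three numbers: its gap to compound 1 is within the scatter, while the step of a 2.6-fold lower number from compound 2 to compound 3 (0.42 log units; beyond the scatter) lies beyond it, the two compounds differing only in configuration as drawn (the fact that compounds 2 and 3 differ only in the configuration as drawn). Compound 4 `COc1ccccc1OC[C@H](C)COc1ccc(C(=O)CC(C)(C)C)c(O)c1C` carries 2-methoxyphenyl in place of 3-carboxy-4-fluorophenyl on an oxygen on a saturated carbon. Among the measured compounds shown here, no measured step bears on this change: the one step measured, a 2.6-fold lower number from compound 2 to compound 3 (0.42 log units; beyond the scatter), concerns configuration alone, and every measured compound keeps the 3-carboxy-4-fluorophenyl. In this assay a step of a 3.1-fold higher number from compound 3 to compound 4 (0.49 log units; beyond the scatter) is therefore expected only loosely. Compound 4 is estimated at 350 nM, within 90 nM to 1400 nM.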

Compound 4, half-maximal effective concentration: "not active" (no number reported)
Nothing numeric was reported for compound 4, and the estimate cannot be compared.
By their numbers in this assay, from the lowest: compounds 3, 1 and 2 (each within the scatter of the next, the first and the last beyond it).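

Among the compounds shown here, compound 4 is reported as not active, without a number, so no step from compound 3 or any other compound to compound 4 can be read, and nothing at hand bears on this result. The compounds shown leave open how 2-methoxyphenyl in place of 3-carboxy-4-fluorophenyl would register numerically in this assay.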